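The source may hold more compounds than are shown below. What is called first, only, known or untested is meant among the compounds shown, and "the series" means these compounds.

Measured compounds in a functional assay on T-24 cells (Homo sapiens) for cytotoxicity, read by CCK-8 assay, with a stated time of 24 h; a lower number here means a stronger inhibitor, a higher number a weaker inhibitor:
Compound 1, `C/C(=C\c1cc(-c2ccc(C)cc2)cs1)C(N)=O`, gives only a limit of the assay, > 50000 nM.
Compound 2, `C/C(=C\c1cc(-c2ccc(S(C)(=O)=O)cc2)cs1)C(N)=O`, gives only a limit, > 50000 nM.
Compound 3, `C/C(=C\c1cc(-c2ccc([N+](=O)[O-])cc2)cs1)C(N)=O`, gives only a limit, > 50000 nM.

Compound 3 thus stands at the limit of > 50000 nM in this assay, at which 3 of the 3 values shown sit, together with every other measured compound. Compound 4, `COc1ccc(-c2csc(/C=C(\C)C(N)=O)c2)cc1`, differs from compound 3 by methoxy in place of nitro on an aromatic carbon. Going by the values given here, the steps that bear on this position, a step that the two limits leave unreadable from compound 1 to compound 3 and a step that the two limits leave unreadable from compound 2 to compound 3, are unreadable, and a step that the two limits leave unreadable from compound 1 to compound 2 is likewise unreadable, so no size or direction of change can be inferred from them. Exchanges at this aromatic carbon have so far not produced a number in this assay. The expectation for compound 4 is therefore a step that the limit leaves unreadable from compound 3 to compound 4 that is not readable. Compound 4 is estimated at 100000 nM, with a range of 30000 nM to 400000 nM, most likely reported again as a limit.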

Compound 4, half-maximal inhibitory concentration: > 50000 nM
Compound 4 was reported as a limit (the forecaster's own chance of this, stated with the estimate: 85%); the middle value does not contradict the limit.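

Going by these compounds alone, compound 4 also gives only a limit, so no step among compound 1, compound 2, compound 3 and compound 4 can be read: the limit of > 50000 nM in this assay, at which 4 of the 4 values shown sit. The compounds shown leave open whether any exchange at this aromatic carbon yields a number in this assay.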